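The source may report more compounds than this note shows. Statements on the series, on what has been measured and on what is new or still open speak of the compounds shown alone.

In a functional assay on MCF7 cells (Homo sapiens) for inhibition, read by MTT assay, with a stated time of 72 h (on this read-out higher numbers stand for weaker inhibition and lower numbers for stronger inhibition), compound 1 `COc1cc(OC)c(OC)cc1/C=C/C(=O)c1ccccc1` gives > 150000 nM, which is a limit of the assay and not a number. Compound 2 `COc1cc(OC)c(OC)cc1/C=C/C(=O)c1cc(Cl)ccc1O` gives > 150000 nM, likewise a limit. For the measured compounds named here, compound 3 `COc1cc(OC)c(OC)cc1/C=C/C(=O)c1ccc(C)cc1` gives 33000 nM, the only true number so far.

Three measured steps connect these compounds. The first is an at least 4.5-fold lower number from compound 1 to compound 3 (0.65 log units; beyond the scatter), with methyl in place of hydrogen on an aromatic carbon. The second is an at least 4.5-fold lower number from compound 2 to compound 3 (0.65 log units; beyond the scatter), with 4-methylphenyl in place of 5-chloro-2-hydroxyphenyl on a carbonyl carbon. The third is a step that the two limits leave unreadable from compound 1 to compound 2.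

Compound 4 `COc1cc(OC)c(OC)cc1/C=C/C(=O)c1cc(O)ccc1O` has yet to be measured in this assay. It carries 2,5-dihydroxyphenyl in place of 4-methylphenyl on a carbonyl carbon. The change removes the 4-methylphenyl of compound 3 and brings in a hydroxylated phenyl, as compound 2 also has. Going by the values given here, the closest precedent is therefore an at least 4.5-fold lower number from compound 2 to compound 3 (0.65 log units; beyond the scatter), run in reverse, and it points towards a higher number and weaker inhibition. On these data alone, since that step is bounded on one side only, its true size remains open. The expected change is an estimated 2.4-fold higher number from compound 3 to compound 4 (0.38 log units; beyond the scatter). For compound 4 the estimated value is 80000 nM, with an expected range from 25000 nM to 200000 nM.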

Compound 4, half-maximal inhibitory concentration: > 150000 nM
Compound 4 gave a limit, no number; the forecaster's own chance of this, stated with the estimate: 40%; middle value at least 1.8-fold (0.27 log units) from the limit.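

In this assay, the two groups on the carbonyl carbon can now be compared directly: 2,5-dihydroxyphenyl in place of 4-methylphenyl gives an at least 4.5-fold higher number from compound 3 to compound 4 (0.65 log units; beyond the scatter). So far, a hydroxylated phenyl at this place was known only from the 5-chloro-2-hydroxyphenyl of compound 2, and compound 4 shows that a hydroxylated phenyl without the chloro also stays at the limit of the assay, so that its steps to compound 1 and compound 2 cannot be read. Among the groups shown on this carbonyl carbon, only the 4-methylphenyl of compound 3 yields a true number, while the unsubstituted phenyl of compound 1 goes against any link between the hydroxy groups alone and the loss of a number: the limit of > 150000 nM in this assay, at which 3 of the 4 values shown sit.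

On these data alone, how far compound 1, compound 2 and compound 4 lie beyond that limit stays open, so no order among them can be given. Also open, as far as these compounds go, is whether the methyl of compound 3 is special, or whether an ethyl, an amine or a carboxylic acid in its place would give a lower or a higher number.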